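Dropping the Methoxy from a Benzylamine Sulfonamide

The source may hold more compounds than are shown below. What is called first, only, known or untested is meant among the compounds shown, and "the series" means these compounds.

Compound 1, `COc1cccc(CNCCCNS(=O)(=O)c2cc(C(F)(F)F)cc(C(F)(F)F)c2)c1`, gives 6400 nM.
Compound 2, `O=S(=O)(NCCCNCc1cccc(Cl)c1)c1cc(C(F)(F)F)cc(C(F)(F)F)c1`, gives 8000 nM.
Compound 3, `COc1ccccc1CNCCCNS(=O)(=O)c1cc(C(F)(F)F)cc(C(F)(F)F)c1`, gives 6000 nM.

All three numbers come from a functional assay on Capan-2 cells (Homo sapiens) for inhibition, read by MTT assay, with a stated time of 72 h; on this read-out lower numbers stand for stronger inhibition of growth and higher numbers for weaker inhibition of growth. Compound 1 sits close to both of the others, and each of its two steps lies within the usual scatter: a 1.3-fold higher number from compound 1 to compound 2 (0.10 log units; within the scatter), and a 1.1-fold lower number from compound 1 to compound 3 (0.03 log units; within the scatter). The step between the other two is within the scatter as well: a 1.3-fold lower number from compound 2 to compound 3 (0.12 log units; within the scatter). Across these three compounds, then, swapping or moving a small group on the benzyl ring has not shifted the read-out in a way that can be told from noise.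

Compound 4, `O=S(=O)(NCCCNCc1ccccc1)c1cc(C(F)(F)F)cc(C(F)(F)F)c1`, has not yet been measured. It differs from compound 1 in one place: hydrogen in place of methoxy on an aromatic carbon. Among the measured compounds shown here, no measured step is this exact change. The nearest guides are the two steps that alter the benzyl ring of compound 1, a 1.3-fold higher number from compound 1 to compound 2 (0.10 log units; within the scatter) and a 1.1-fold lower number from compound 1 to compound 3 (0.03 log units; within the scatter), both within the scatter. On that basis no step beyond the scatter is expected in this assay in either direction, and the estimate for compound 4 is 7000 nM, expected to fall between 3000 nM and 16000 nM. The expected step, a 1.1-fold higher number from compound 1 to compound 4 (0.04 log units; within the scatter), is essentially flat.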

Compound 4, concentration for 50% growth inhibition: 14000 nM
For compound 4 the middle estimate is 2.0-fold (0.30 log units) below the measured one, and the stated range covers the measured number.
By their numbers in this assay, from the lowest: compounds 3, 1, 2 and 4 (each within the scatter of the next, the first and the last beyond it).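

Taking the methoxy group off altogether does what moving it or swapping it for chloro did not: in this assay it gives a 2.2-fold higher number from compound 1 to compound 4 (0.34 log units; beyond the scatter), and the same change on the other methoxy compound gives a 2.3-fold higher number from compound 3 to compound 4 (0.37 log units; beyond the scatter), both modest but beyond the scatter. Replacing chloro with hydrogen gives a 1.8-fold higher number from compound 2 to compound 4 (0.24 log units; within the scatter), which stays within the scatter, so the bare benzyl ring can be told apart from the two methoxy-bearing rings but not from the chloro-bearing one, and compound 2 cannot be separated from any of the other three. A methoxy group on this ring therefore goes with a lower number than hydrogen in these compounds, but no measurement here bears on the reason.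

As far as these compounds go, it remains open whether other small groups on the ring, such as fluoro, methyl or hydroxyl, would group with the methoxy compounds or with compound 4. It is also open whether a longer chain, or an amide in place of the amine, would move the read-out further than any ring change shown here.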